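The source may report more compounds than this note shows. Statements on the series, on what has been measured and on what is new or still open speak of the compounds shown alone.

Measured in a functional assay on NALM-6 cells (Homo sapiens) for cytotoxicity, read by MTT assay, with a stated time of 46 h; on this read-out higher numbers stand for weaker inhibition and lower numbers for stronger inhibition:
- compound 1 `O=C1/C(=C/c2ccncc2)C(c2ccccc2)Oc2ccccc21` gives 1600 nM
- compound 2 `O=C1/C(=C\c2ccccc2)C(c2ccccc2)Oc2ccccc21` gives > 1000000 nM
- compound 3 `O=C1/C(=C/c2ccccc2)C(c2ccccc2)Oc2ccccc21` gives 29500 nM

The entry for compound 2 is a limit of the assay and not a number. Of the two true numbers, compound 3 holds the higher one, and the other belongs to compound 1.

Compound 4 `O=C1/C(=C/c2ccccc2)C(c2ccccc2)Oc2ccc(O)cc21` differs from compound 3 by a single change, hydroxy in place of hydrogen on an aromatic carbon. Going by the values given here, no measured step touches this place, so none gives its size directly. Among the compounds with values here, two steps bear on it only indirectly. One is an 18-fold higher number from compound 1 to compound 3 (1.27 log units; beyond the scatter), and the other is an at least 33-fold lower number from compound 2 to compound 3 (1.53 log units; beyond the scatter). Both are large, which shows that this assay can respond strongly to one local change on the shared core. They give no direction for a hydroxy group, so only a moderate shift towards a lower number is expected, with a wide margin. The expected change is a 2.5-fold lower number from compound 3 to compound 4 (0.39 log units; beyond the scatter). For compound 4 the estimated value is 12000 nM, with an expected range from 2500 nM to 50000 nM.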

Compound 4, half-maximal inhibitory concentration: 8700 nM
Compound 4: the middle estimate sits 1.4-fold (0.14 log units) above what was measured; low and high end bracket the measured number.
By their numbers in this assay, from the lowest: compound 1; then compound 4; then compound 3. At a limit, above all of these: compound 2.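

In this assay, hydroxy in place of hydrogen on an aromatic carbon, meta to a fused ring and para to a fused ring, gives a 3.4-fold lower number from compound 3 to compound 4 (0.53 log units; beyond the scatter). Going by these compounds alone, this is the first evidence on this part of the shared core, since the earlier steps concerned only the group on the double-bonded chain carbon and the drawing of the double bond, and it shows that the number responds modestly, towards stronger inhibition, to a hydroxy group here. Nothing given here accounts for why this shift occurs. Open, going by these compounds, is whether a methoxy group, an amine or a carboxylic acid on the same aromatic carbon would shift the number in the same direction. Also open, on these data alone, is whether the hydroxy group would have a similar effect with pyridin-4-yl in place of phenyl.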